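The source may report more compounds than this note shows. Statements on the series, on what has been measured and on what is new or still open speak of the compounds shown alone.

Measured so far:
- compound 1, `CCOC(=O)c1sc(-c2cccc(NC(=O)c3ccc(C(C)(C)C)cc3)c2)nc1Nc1ccc(N2CCN(C)CC2)cc1` — "not determined" (no result reported)
- compound 2, `CCOC(=O)c1sc(-c2cccc(NC(=O)[C@H]3CC[C@H](C)CC3)c2)nc1Nc1ccc(N2CCN(C)CC2)cc1` — "not determined" (no result reported)
- compound 3, `CN1CCN(c2ccc(Nc3nc(-c4cccc(NC(=O)c5ccc(C(C)(C)C)cc5)c4)sc3C(N)=O)cc2)CC1` — 8600 nM

Three compounds share one core, an ethyl ester or a primary amide on the ring carrying the substituted anilino group, with a benzamide-type substituent on the aryl ring. Going by the values given here, in a functional assay on Ramos cells (Homo sapiens) for antiproliferative activity, read by CCK-8 assay, with a stated time of 72 h (a higher number here means a weaker inhibitor, a lower number a stronger inhibitor), compound 3 gives 8600 nM; for compound 1 and compound 2 no result was reported in this assay, so compound 3 carries the only number the series shows and stands alone, with nothing to order it against.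

Compound 4, `CN1CCN(c2ccc(Nc3nc(-c4cccc(NC(=O)c5ccc(F)c(Cl)c5)c4)sc3C(N)=O)cc2)CC1`, is the next entry to be measured in this assay. Against compound 3 the difference is 3-chloro-4-fluorophenyl in place of 4-(tert-butyl)phenyl on a carbonyl carbon. Among the compounds with values here, no pair of measured compounds with a single difference exists, so no step size is known for any change. The amide attached to the aryl ring remains, and only the aromatic group on the carbonyl carbon changes. Within the data shown here, with no step to lean on, the expectation for the move from compound 3 to compound 4 is no shift beyond the usual scatter, a 1.2-fold higher number from compound 3 to compound 4 (0.07 log units; within the scatter), as an estimate. For compound 4 in this assay the estimated value is 10000 nM, expected within the range 3000 nM to 30000 nM.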

Compound 4, half-maximal inhibitory concentration: 4830 nM
Beside the measured number, compound 4's estimate is 2.1-fold (0.32 log units) above it; low and high end bracket the measured number.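

In this assay, 3-chloro-4-fluorophenyl in place of 4-(tert-butyl)phenyl on a carbonyl carbon gives a 1.8-fold lower number from compound 3 to compound 4 (0.25 log units; within the scatter), the first step the series offers, and it leaves the two compounds indistinguishable in this read-out. For this one pair, the group on the carbonyl carbon can go from 10 heavy atoms, all carbon, to 8 heavy atoms that include one chlorine and one fluorine without a shift beyond the scatter, so a single exchange of one aromatic group for another, with the amide kept, gives no handle on potency here. No supporting measurement bears on this result, so nothing can be said about what lies behind it.

On these data alone, it remains open whether an amine such as a dimethylaminomethyl group on that phenyl ring, or a saturated ring such as piperidine in place of the phenyl ring on the carbonyl carbon, would give a step beyond the scatter. Also open, as far as these compounds go, is how a carboxylic acid in place of the primary amide on the shared core would read in this assay.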